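Adding a Second Methyl Where Little Is Known

A few compounds are considered here, and "the series" means these few. Any claim that something is new, unique, unknown or untested is made for them only; others in the source may bear on it.

Compound 1 `Cc1cc(Cl)cc(-c2ccnc3cc(CN4C(=O)C5C(C4=O)C5(C)C)sc23)c1C[C@@H]1CNCCO1`: 450 nM
Compound 2 `Cc1cc(Cl)cc(-c2ccnc3cc(CN4C(=O)C5CC5C4=O)sc23)c1C[C@@H]1CNC[C@@H](C)O1`: "not determined" (no result reported)
Compound 3 `Cc1cc(Cl)cc(-c2ccnc3cc(CN4C(=O)CCC4=O)sc23)c1CN1CCNC[C@@H]1C`: "not determined" (no result reported)

In a functional assay on NCI-H526 cells (Homo sapiens) for cytotoxicity, read by CellTiter-Glo, with a stated time of 5 days (a higher number here means that more compound is tolerated, a lower number that less compound is tolerated), compound 1 gives 450 nM. Compound 2 stands as "not determined" (no result reported) in this assay. Compound 3 also stands as "not determined" (no result reported) in this assay, so there is no measured anchor for it, and it is one of two compounds here without a result. Compound 4 `Cc1cc(Cl)cc(-c2ccnc3cc(CN4C(=O)CCC4=O)sc23)c1CN1[C@@H](C)CNC[C@@H]1C` has not yet been measured in this assay. The change from compound 3 to compound 4 is methyl in place of hydrogen on a saturated ring carbon, leaving 2-methylpiperazin-1-yl in compound 3 as 2,6-dimethylpiperazin-1-yl in compound 4. Among the measured compounds shown here, no step between measured compounds is available, and compound 3 itself has no value, so no direction can be read from the data; an added methyl of this kind is expected to give a step within the usual scatter of this assay, in no set direction. Resting only on compound 1, which differs in several places, compound 4 is expected to give about 600 nM in this assay, within a wide range from 100 nM to 4000 nM.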

Compound 4, half-maximal cytotoxic concentration: 2200 nM
The estimate for compound 4 lay 3.7-fold (0.56 log units) below the measured number; measured number inside the range.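

In this assay, among the compounds shown here, compound 4 gives 2200 nM but compound 3 has no result, and no step from compound 3 to compound 4 can be read. No other data shown bear on this result. The compounds shown leave open what the added methyl does in this assay.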